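The source may hold more compounds than are shown below. What is called first, only, known or untested is meant among the compounds shown, and "the series" means these compounds.

Four compounds share one core and differ only in the length of a straight alkyl chain on the aromatic ring. Compound 1 `CCCCCc1ccc(-c2c(C)[nH]c(=O)n2C2CCCCC2)cc1` carries the shortest chain; compound 2 `CCCCCCCc1ccc(-c2c(C)[nH]c(=O)n2C2CCCCC2)cc1`, compound 3 `CCCCCCCCCCCCc1ccc(-c2c(C)[nH]c(=O)n2C2CCCCC2)cc1` and compound 4 `CCCCCCCCCCCCCCc1ccc(-c2c(C)[nH]c(=O)n2C2CCCCC2)cc1` carry longer ones. In a functional assay on brain (Rattus norvegicus, strain Wistar) for inhibition (a higher number here means a weaker inhibitor, a lower number a stronger inhibitor), compound 1 gives 10600 nM. Compound 2 gives 8700 nM; the step of a 1.2-fold lower number from compound 1 to compound 2 (0.09 log units; within the scatter) comes with the change (ethyl in place of hydrogen on a saturated chain carbon, five bonds along the chain from an aromatic carbon). For compound 3 the result is only a limit of the assay, > 100000 nM. From compound 1 to compound 3 the difference is heptyl in place of hydrogen on a saturated chain carbon, five bonds along the chain from an aromatic carbon, and the step is an at least 9.4-fold higher number from compound 1 to compound 3 (0.97 log units; beyond the scatter). From compound 2 to compound 3 the step is an at least 11-fold higher number from compound 2 to compound 3 (1.06 log units; beyond the scatter). Compound 4 differs from compound 3 by ethyl in place of hydrogen on a saturated chain carbon, ten or more bonds along the chain from an aromatic carbon, the same kind of change as from compound 1 to compound 2, though the place along the chain differs. The earlier step stayed within the scatter, but compound 3 already sits at the limit (the limit of > 100000 nM in this assay, at which 1 of the 3 values shown sits), so compound 4 is expected to stay there too, with an estimated step that the limit leaves unreadable from compound 3 to compound 4. The estimate for compound 4 in this assay is 250000 nM, expected between 100000 nM and 1000000 nM.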

Compound 4, half-maximal inhibitory concentration: > 100000 nM
Compound 4: only a limit was reported (the forecaster's own chance of this, stated with the estimate: 85%); the middle value does not contradict the limit.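

In this assay, the longest chain gives an at least 11-fold higher number from compound 2 to compound 4 (1.06 log units; beyond the scatter), and the comparison with the shortest chain gives an at least 9.4-fold higher number from compound 1 to compound 4 (0.97 log units; beyond the scatter). Adding heptyl weakens inhibition from both starting chains, so the direction of this change carries over between these two closely related compounds: the same change on two cores in this assay, an at least 9.4-fold higher number (0.97 log units; beyond the scatter) from compound 1 to compound 3 and an at least 11-fold higher number (1.06 log units; beyond the scatter) from compound 2 to compound 4; the limit leaves it open whether they differ This does not show that the loss is the same size in both cases, and the step between the two longest chains cannot be read, since both of those compounds sit at a limit of the assay: the limit of > 100000 nM in this assay, at which 2 of the 4 values shown sit.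

The compounds shown leave open how much inhibition a decyl chain would keep, and so where between the chain of compound 2 and the chain of compound 3 the loss sets in. As far as these compounds go, it also remains open whether a chain carrying a carboxylic acid or an amine would follow the same trend as these plain alkyl chains.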